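The source may hold more compounds than are shown below. What is called first, only, known or untested is meant among the compounds shown, and "the series" means these compounds.

Measured in an assay on CHO cells for displacement of a labelled ligand from adenosine receptor A1 (Homo sapiens), read by scintillation counting, with a stated time of 1 h, tested at 1 uM; on this read-out lower numbers stand for less inhibition and higher numbers for more inhibition at the one concentration tested (going by the name of the read-out):

compound 1, `CC(C)CC(=O)Nc1ncc(-c2cccc(Cl)c2)c(-c2ccccc2)n1`: 56%
compound 2, `O=C(Nc1ncc(-c2cccc(Cl)c2)c(-c2ccccc2)n1)C1CCCC1`: 47%
compound 3, `CNc1ncc(-c2cccc(Cl)c2)c(-c2ccccc2)n1`: 75%

Compound 3 stands highest of the three numbers. The step of a number 19 percentage points higher from compound 1 to compound 3 (beyond the scatter) and the step of a number 28 percentage points higher from compound 2 to compound 3 (beyond the scatter) are both beyond the scatter, whereas a number 9 percentage points lower from compound 1 to compound 2 (within the scatter) is within it, so the two acylated compounds cannot be ordered against each other, and only compound 3 separates from the rest.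

Compound 4, `OCCCNc1ncc(-c2cccc(Cl)c2)c(-c2ccccc2)n1`, has not been measured. It differs from compound 3 in one place: 2-hydroxyethyl in place of hydrogen on a saturated chain carbon bound to a nitrogen on an aromatic ring.

Both steps beyond the scatter concern the substituent on the nitrogen on the aromatic ring, where a methyl took the place of an isobutylcarbonyl or a cyclopentylcarbonyl and the number rose modestly. Among the compounds with values here, no measured pair lengthens the chain on that nitrogen or brings in a hydroxyl, so those steps bear on compound 4 only loosely: they show that the number changes with the substituent on this nitrogen, with the smaller group giving the higher number, but say nothing about a 3-hydroxypropyl in place of methyl. The expected step of a number 13 percentage points lower from compound 3 to compound 4 (beyond the scatter) is therefore small, likely within the scatter, with a slight lean downward. Compound 4 is estimated at 62%, in the range 42% to 82%.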

Compound 4, a percentage reported as inhibition, at one concentration (the size of the read-out at that concentration, not a potency): > 80%
Compound 4: no number, only a limit; the forecaster's own chance of this, stated with the estimate: 0%; middle value at least 18 percentage points away from the limit.
By their numbers in this assay, from the lowest: compounds 2 and 1 (each within the scatter of the next); then compound 3. At a limit, above all of these: compound 4.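

In this assay compound 4 is reported only as a limit, not a number: the limit of > 80% in this assay, at which 1 of the 4 values shown sits. The change from methyl to 3-hydroxypropyl on the nitrogen on the aromatic ring gives a number at least 5 percentage points higher from compound 3 to compound 4 (that floor lies within the scatter) and so brings no loss at this position, which means the number does not simply fall as the group on this nitrogen grows, a reading that compounds 1, 2 and 3 alone had allowed. Replacing either acyl group with the 3-hydroxypropyl gives a number at least 33 percentage points higher from compound 2 to compound 4 (beyond the scatter) and a number at least 24 percentage points higher from compound 1 to compound 4 (beyond the scatter), so both compounds with a plain chain on this nitrogen, compound 3 and compound 4, stand clear of the two amides, and none of the four compounds goes against this split.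

Going by these compounds, how far compound 4 really stands from compound 3 stays open behind the limit, and the chain length and the hydroxyl cannot be told apart with a single compound carrying both. A plain propyl chain, a longer hydroxyalkyl chain, or an amine or a carboxylic acid at the chain end would separate these two contributions.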